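This account rests on a few compounds, and the source may have more. Where it says the series, first, only, none or still open, it means among the compounds named here.

Compound 3 `COc1ccc(Cc2ccc3cc(NC(=O)c4ccc(OC(C)=O)c(CC=C(C)C)c4)c(=O)oc3c2C)cc1` gives 23500 nM in a functional assay on SK-BR-3 cells (Homo sapiens) for antiproliferative activity (a higher number here means a weaker inhibitor, a lower number a stronger inhibitor), the lowest of the three numbers in hand, but within the scatter of compound 2 `COc1cccc(Oc2ccc3cc(NC(=O)c4ccc(O)c(CC=C(C)C)c4)c(=O)oc3c2C)c1` at 33100 nM and of compound 1 `COc1ccc(Oc2ccc3cc(NC(=O)c4ccc(O)c(CC=C(C)C)c4)c(=O)oc3c2C)cc1` at 42700 nM. Going by the values given here, the only measured step, a 1.3-fold lower number from compound 1 to compound 2 (0.11 log units; within the scatter), concerns the methoxyphenyl and does not bear on the change now in question. Compound 4 `COc1ccc(Cc2ccc3cc(NC(=O)c4ccc(O)c(CC=C(C)C)c4)c(=O)oc3c2C)cc1` differs from compound 3 by hydrogen in place of acetyl on an oxygen on an aromatic ring. Compounds 1 and 2 carry the free hydroxy and their values sit close to compound 3, so no step beyond the scatter is expected in this assay. The estimate for compound 4 in this assay is 28000 nM, with a range from 10000 nM to 70000 nM, corresponding to an expected step of a 1.2-fold higher number from compound 3 to compound 4 (0.08 log units; within the scatter).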

Compound 4, half-maximal inhibitory concentration: 11100 nM
Compound 4: the middle estimate sits 2.5-fold (0.40 log units) above what was measured; the measured number falls inside the stated range.
By their numbers in this assay, from the lowest: compound 4; then compounds 3, 2 and 1 (each within the scatter of the next).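

In this assay, going by these compounds alone, the change from acetoxy to hydroxy gives a 2.1-fold lower number from compound 3 to compound 4 (0.33 log units; beyond the scatter) and is the first step at this oxygen to lie beyond the scatter, so the free hydroxy outperforms the acetate in this pair. With the hydroxy held, 4-methoxybenzyl in place of 3-methoxyphenoxy gives a 3.0-fold lower number from compound 2 to compound 4 (0.47 log units; beyond the scatter) and in place of 4-methoxyphenoxy gives a 3.8-fold lower number from compound 1 to compound 4 (0.59 log units; beyond the scatter) as two further modest steps. Nothing in hand accounts for these steps.

Open, on these data alone, is whether a methyl ether or an amine in place of the hydroxy holds this level. Also open, as far as these compounds go, is whether acetoxy to hydroxy behaves alike when the methoxyphenoxy groups are present.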